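From Ethyl to Acetamido: a Step Without Precedent

A few compounds are considered here, and "the series" means these few. Any claim that something is new, unique, unknown or untested is made for them only; others in the source may bear on it.

compound 1, `CCc1cccc(Nc2nccc(-c3ccco3)n2)c1`: 9700 nM
compound 2, `CCc1cccc(Nc2nccc(-c3ccccn3)n2)c1`: 1400 nM
compound 3, `CCc1cccc(Nc2nccc(-c3ccncc3)n2)c1`: 10600 nM

In a functional assay for inhibition, with Homo sapiens as the target (a higher number here means a weaker inhibitor, a lower number a stronger inhibitor), compound 3 gives the highest of the three numbers. Its gap to compound 1 lies within the scatter, whereas the step of a 7.6-fold higher number from compound 2 to compound 3 (0.88 log units; beyond the scatter) lies beyond it. Compound 4, `CC(=O)Nc1cccc(Nc2nccc(-c3ccncc3)n2)c1`, differs from compound 3 by acetamido in place of ethyl on an aromatic carbon. The measured steps of a 6.9-fold lower number from compound 1 to compound 2 (0.84 log units; beyond the scatter), a 1.1-fold higher number from compound 1 to compound 3 (0.04 log units; within the scatter) and a 7.6-fold higher number from compound 2 to compound 3 (0.88 log units; beyond the scatter) each exchange one aromatic ring for another, and none touches the ethyl group. Among the compounds with values here, no measured step therefore bears on this change. With nothing to point either way, the step of a 1.2-fold lower number from compound 3 to compound 4 (0.07 log units; within the scatter) is expected to stay within the scatter, though with little confidence. Compound 4 is estimated at 9000 nM, within a range from 2000 nM to 40000 nM.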

Compound 4, half-maximal inhibitory concentration: 2700 nM
The estimate for compound 4 lay 3.3-fold (0.52 log units) above the measured number; the range from low to high includes it.
By their numbers in this assay, from the lowest: compounds 2 and 4 (each within the scatter of the next); then compounds 1 and 3 (each within the scatter of the next).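

In this assay, the change of acetamido in place of ethyl gives a 3.9-fold lower number from compound 3 to compound 4 (0.59 log units; beyond the scatter), so this place, on an aromatic carbon meta to a large group, responds to substitution. The earlier steps shown here only exchanged one aromatic ring for another and showed nothing about this place. No available evidence accounts for the size of this step.

On these data alone, whether acetamido has the same effect alongside pyridin-2-yl or furan-2-yl remains open. So does how an amine, a carboxylic acid or a longer chain would compare at this place.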